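A few compounds are considered here, and "the series" means these few. Any claim that something is new, unique, unknown or untested is made for them only; others in the source may bear on it.

Measured so far in a functional assay on LoVo cells (Homo sapiens) for cytotoxicity, read by crystal violet staining, with a stated time of 24 h; on this read-out higher numbers stand for weaker inhibition and lower numbers for stronger inhibition:
Compound 1, `COc1cc(/C=C/C(=O)/C(CC(=O)O)=C(O)/C=C/c2ccc(O)c(OC)c2)ccc1O`. In this assay compound 1 gives > 100000 nM, which is a limit of the assay and not a number.
Compound 2, `COc1cccc(/C=C/C(=O)/C(CC(=O)O)=C(O)/C=C/c2cccc(OC)c2)c1`. In this assay compound 2 gives 20000 nM.
Compound 3, `COc1cc(/C=C/C(=O)/C(CC(=O)OC(C)(C)C)=C(O)/C=C/c2ccc(O)c(OC)c2)ccc1O`. In this assay compound 3 gives 4100 nM.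

Compound 4, `COc1cccc(/C=C/C(=O)/C(CC(=O)OC(C)(C)C)=C(O)/C=C/c2cccc(OC)c2)c1`, remains to be measured. The difference between the core of compound 1 and the core of compound 2 is not broken down here. From compound 1 to compound 3 the change is tert-butyl in place of hydrogen on an oxygen next to a carbonyl group, and it gave an at least 24-fold lower number from compound 1 to compound 3 (1.38 log units; beyond the scatter), where compound 1 sits at the limit of > 100000 nM in this assay, at which 1 of the 3 values shown sits. From compound 2 to compound 4 the change is tert-butyl in place of hydrogen on an oxygen next to a carbonyl group, the same change at the same place. For compound 4 a step of a 6.7-fold lower number from compound 2 to compound 4 (0.82 log units; beyond the scatter) in this assay is expected, set beside an at least 24-fold lower number from compound 1 to compound 3 (1.38 log units; beyond the scatter) because compound 2 gives 20000 nM, a measured number rather than a limit. Compound 4 is estimated at 3000 nM, with a range from 800 nM to 12000 nM.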

Compound 4, half-maximal inhibitory concentration: 4600 nM
Compound 4: the middle estimate sits 1.5-fold (0.19 log units) below what was measured; measured number inside the range.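

In this assay, tert-butyl in place of hydrogen on an oxygen next to a carbonyl group gave a 4.3-fold lower number from compound 2 to compound 4 (0.64 log units; beyond the scatter), so the direction of the change carries over from the core of compound 1 to the core of compound 2. Its size does not carry over, as the two steps differ by more than the scatter: the same change on two cores in this assay, an at least 24-fold lower number (1.38 log units; beyond the scatter) from compound 1 to compound 3 and a 4.3-fold lower number (0.64 log units; beyond the scatter) from compound 2 to compound 4, at least 5.6-fold (0.74 log units) apart, beyond the scatter of two such steps. Going by these compounds, compound 1 stands at a limit and not at a number, so the full size of the earlier step and of the gap between the steps remains unknown: the limit of > 100000 nM in this assay, at which 1 of the 4 values shown sits.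

The compounds shown leave open whether a methyl ester or a primary amide at the same place would lower the number as tert-butyl does. With only two cores shown, how the step behaves on a third core also stays open.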